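Replacing 3,4-dihydroxyphenyl with 4-hydroxycyclohexyl in the series

A few compounds are considered here, and "the series" means these few. Any claim that something is new, unique, unknown or untested is made for them only; others in the source may bear on it.

Values so far in a functional assay on HL-60 cells (Homo sapiens) for inhibition, read by CCK-8 assay, with a stated time of 48 h (a lower number here means a stronger inhibitor, a higher number a weaker inhibitor), are these
- compound 1 `COc1ccc(Oc2ccc(C(C)C)cc2-c2ccsc2S(=O)(=O)NCCNC(=S)Nc2ccc([N+](=O)[O-])cc2)cc1OC` gives 11200 nM
- compound 2 `O=C(NCCNS(=O)(=O)c1ccc(-c2ccccc2Oc2ccc(O)c(O)c2)s1)Nc1cc(Cl)cc(Cl)c1` gives 10400 nM

Compound 2 and compound 1 lie within the scatter of each other, so their two numbers set no order between them. The next compound to consider is compound 3 `O=C(NCCNS(=O)(=O)c1ccc(-c2ccccc2O[C@H]2CC[C@H](O)CC2)s1)Nc1cc(Cl)cc(Cl)c1`, which differs from compound 2 in one place: 4-hydroxycyclohexyl in place of 3,4-dihydroxyphenyl on an oxygen on an aromatic ring. Here 4-hydroxycyclohexyl stands in place of 3,4-dihydroxyphenyl on an oxygen on an aromatic ring, so a six-membered non-aromatic ring replaces a six-membered aromatic one. For the measured compounds named here, the only anchor is compound 2 at 10400 nM and no measured step tests this position. The expected 1.3-fold higher number from compound 2 to compound 3 (0.13 log units; within the scatter) is therefore small, a slightly higher number in this assay or none beyond the scatter. The estimated value for compound 3 is 14000 nM (expected range 5000 nM to 40000 nM).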

Compound 3, half-maximal inhibitory concentration: > 20000 nM
Compound 3 was reported as a limit; the forecaster's own chance of this, stated with the estimate: 20%; at least 1.4-fold (0.15 log units) between middle value and limit.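

In this assay compound 3 is reported only as a limit, > 20000 nM, and not as a number. This gives the only step at this position, the oxygen on an aromatic ring, and it reads an at least 1.9-fold higher number from compound 2 to compound 3 (0.28 log units; that floor lies within the scatter); as that floor lies within the scatter, replacing 3,4-dihydroxyphenyl with 4-hydroxycyclohexyl is not shown to weaken inhibition, although the limit gives no sign of a gain. From the compounds shown here alone, the true size of the step stays open, bounded from one side only: the limit of > 20000 nM in this assay, at which 1 of the 3 values shown sits.

Going by these compounds, whether a single hydroxyl on the aromatic ring, as in 4-hydroxyphenyl, would keep the number of compound 2 at 10400 nM remains open. Also open, on these data alone, is how an amine such as 4-aminocyclohexyl would read on the same oxygen.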